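A few compounds are considered here, and "the series" means these few. Any claim that something is new, unique, unknown or untested is made for them only; others in the source may bear on it.

Measured compounds:
compound 1 `O=C(CSc1nncnc1-c1cccc2ccccc12)Nc1ccccc1Br`: 87000 nM in an ADME assay on MT4 cells (Homo sapiens) for cytotoxicity, read by MTT assay; on this read-out higher numbers stand for lower toxicity in this test and lower numbers for higher toxicity in this test
compound 2 `COC(=O)c1ccc(NC(=O)CSc2nncnc2-c2ccccc2Cl)c(Br)c1`: 59000 nM in this assay

Compound 1 has the higher of the two numbers in this assay, but the gap to compound 2 is within the usual scatter, so no real difference is shown. Compound 3 `Cc1ccccc1NC(=O)CSc1nncnc1-c1cccc2ccccc12` is not yet measured; it differs from compound 1 by methyl in place of bromo on an aromatic carbon. Within the data shown here, no measured pair shows this change, so its effect is unknown; a step of no more than the scatter, in either direction, is the plainest expectation. Compound 3 is therefore estimated at 80000 nM in this assay, within 30000 nM to 200000 nM, an expected step of a 1.1-fold lower number from compound 1 to compound 3 (0.04 log units; within the scatter).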

Compound 3, half-maximal cytotoxic concentration: 158000 nM
Estimate against measurement, compound 3: 2.0-fold (0.30 log units) below; low and high end bracket the measured number.
By their numbers in this assay, from the lowest: compounds 2, 1 and 3 (each within the scatter of the next, the first and the last beyond it).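

In this assay, putting methyl in place of bromo on this aromatic carbon, ortho to a large group, gives a 1.8-fold higher number from compound 1 to compound 3 (0.26 log units; within the scatter). Among these compounds, this is the first direct look at this change, and it shows that this place accepts either group without a real difference in the read-out. No measurement at hand offers an explanation for this result.

Going by these compounds, whether an amine, a carboxylic acid or a longer chain at this place would also stay within the scatter remains open. So does whether the same change behaves alike on a different core.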